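This account rests on a few compounds, and the source may have more. Where it says the series, first, only, none or still open, it means among the compounds named here.

Measured so far:
compound 1, `C[C@H]1OCC[C@@H](C[N+](C)(C)C)O1`: 1
compound 2, `C[C@H]1CSC[C@@H](C[N+](C)(C)C)O1`: 1

In a functional assay on ileum for agonist activity at muscarinic acetylcholine receptor M3 (Cavia porcellus) (on this read-out lower numbers stand for smaller maximal responses and higher numbers for larger maximal responses), compound 1 gives 1. In this assay compound 2 gives 1, level with compound 1 at the digits shown, the two values lying within the usual scatter of each other. Within the data shown here, no step between measured compounds that differ in one place is available, so no measured step sets a scale for what follows.

Compound 3, `C[C@H]1CSC[C@H](C[N+](C)(C)C)O1`, is not yet measured in this assay. It differs from compound 2 as follows: the two compounds have the same atoms and bonds and differ only in configuration as drawn: 1 of 2 stereo elements differ; a stereocentre at a saturated ring carbon is drawn R in compound 2 and S in compound 3.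

Among the measured compounds shown here, with both measured compounds at the same level, the only guide is the change of configuration itself. It is expected either to lower the maximal response somewhat or to leave it where compound 2 stands at 1. The step a number 0.10 lower from compound 2 to compound 3 (within the scatter) is therefore expected to be a modest fall, within or just beyond the scatter. Compound 3 is estimated at 0.9, with a range of 0.5 to 1.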

Compound 3, intrinsic activity: the largest response reached, as a fraction of the reference agonist's: 1
For compound 3 the middle estimate is 0.10 below the measured one; the range from low to high includes it.
By their numbers in this assay, from the lowest: compounds 1, 2 and 3 (each within the scatter of the next).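

In this assay, among these compounds, this is the first single change that can be read, and the step shows no change at the digits printed from compound 2 to compound 3 (within the scatter). At this saturated ring carbon, a stereocentre drawn R or S therefore gives no difference in maximal response that this read-out can separate. The comparison isolates that one stereocentre, since nothing else varies: the fact that compounds 2 and 3 differ only in the configuration as drawn

The maximal response alone leaves open whether compound 2 and compound 3 also match in the concentration needed to reach it, and whether the other stereocentre behaves in the same way. Going by these compounds, it also remains open whether the maximal response would hold with a tertiary amine in place of the trimethylammonium group, or with an ethyl group in place of the ring methyl.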